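Trifluoromethylcarbonyl for methyl on the shared core

A few compounds are considered here, and "the series" means these few. Any claim that something is new, unique, unknown or untested is made for them only; others in the source may bear on it.

Compound 1, `Cc1cc(S(=O)(=O)NC(=O)c2ccc(N3CCN(Cc4ccccc4-c4ccc(Cl)cc4)CC3)cc2)ccc1N[C@H](CCN(C)C)CSc1ccccc1`, carries a methyl on the ring that bears the acylsulfonamide-linked aryl amine. In an ADME assay on the whole organism (plasma, strain Sprague-Dawley) for pharmacokinetics, with Rattus norvegicus as the target, at a dose of 5 mg/kg by the oral route (on this read-out higher numbers stand for higher exposure at the dose given and lower numbers for lower exposure), compound 1 gives "not determined" (no result reported); no result was reported for it, so it stands nowhere on the exposure scale shown here. Two relatives of the shared core do carry numbers. Compound 2, `CN(C)CC[C@H](CSc1ccccc1)Nc1ccc(S(=O)(=O)NC(=O)c2ccc(N3CCN(CC4=C(c5ccc(Cl)cc5)CCCC4)CC3)cc2)cc1[N+](=O)[O-]`, gives 531 ng.h/mL in this assay. For the measured compounds named here, compound 3, `O=C(NS(=O)(=O)c1ccc(NCCSc2ccccc2)c([N+](=O)[O-])c1)c1ccc(N2CCN(Cc3ccccc3-c3ccc(Cl)cc3)CC2)cc1`, gives 7720 ng.h/mL in this assay; the two values differ by a wide margin, but no step between them is tabulated, so only the pair of readings can be noted.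

Compound 4, `CN(C)CC[C@H](CSc1ccccc1)Nc1ccc(S(=O)(=O)NC(=O)c2ccc(N3CCN(Cc4ccccc4-c4ccc(Cl)cc4)CC3)cc2)cc1C(=O)C(F)(F)F`, is the unmeasured member. It differs from compound 1 by (trifluoromethyl)carbonyl in place of methyl on an aromatic carbon; the group enters on an aromatic carbon of a six-membered aromatic ring of carbon only, ortho to a large group and meta to a large group. With no number for compound 1, no size or direction of step in this assay can be set against a measured starting point; the expectation rests on compound 2 and compound 3 alone. Compound 4 is expected to fall near 800 ng.h/mL, within a range of 150 ng.h/mL to 4000 ng.h/mL, because compound 2 at 531 ng.h/mL shares the same amine side chain.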

Compound 4, area under the concentration-time curve: 1080 ng.h/mL
The estimate for compound 4 lay 1.4-fold (0.13 log units) below the measured number; measured number inside the range.
By their numbers in this assay, from the lowest: compound 2; then compound 4; then compound 3.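

In this assay, for the compounds shown here, compound 1 carries no number, so no step to compound 4 can be read from this result. Nothing shown offers an explanation for the reading of compound 4. The compounds shown leave open how exposure changes when (trifluoromethyl)carbonyl replaces methyl on the shared core.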